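The source may hold more compounds than are shown below. What is called first, only, known or untested is meant among the compounds shown, and "the series" means these compounds.

Compound 1 `O=C(NCc1ccc(C(F)(F)F)nc1N1CCCC1)Nc1cccc2[nH]c(=O)ccc12`: 0.94 nM
Compound 2 `O=C(NCc1ccc(C(F)(F)F)nc1SC1CCCCC1)Nc1cccc2[nH]c(=O)ccc12`: 2.15 nM

In an assay on HEK cells for antagonist activity at transient receptor potential cation channel subfamily V member 1 (Homo sapiens), read by FLIPR (a higher number here means a weaker inhibitor, a lower number a stronger inhibitor), compound 1 gives 0.94 nM, the lowest of the two numbers shown; compound 2 gives 2.15 nM, and the step of a 2.3-fold higher number from compound 1 to compound 2 (0.36 log units; beyond the scatter) was modest. Compound 3 `CC1CCC(c2nc(C(F)(F)F)ccc2CNC(=O)Nc2cccc3[nH]c(=O)ccc23)CC1` differs from compound 1 by 4-methylcyclohexyl in place of pyrrolidin-1-yl on an aromatic carbon. For the measured compounds named here, that earlier step is the only one bearing on this change, as it too exchanged pyrrolidin-1-yl for a six-membered non-aromatic ring of carbon only at the same place. Compound 3 is therefore expected to show a modest rise, a 2.1-fold higher number from compound 1 to compound 3 (0.33 log units; beyond the scatter), with an estimate of 2 nM ranging from 0.7 nM to 6 nM.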

Compound 3, half-maximal inhibitory concentration: 1.44 nM
Beside the measured number, compound 3's estimate is 1.4-fold (0.14 log units) above it, within the range that was stated.
By their numbers in this assay, from the lowest: compounds 1, 3 and 2 (each within the scatter of the next, the first and the last beyond it).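

In this assay, 4-methylcyclohexyl in place of pyrrolidin-1-yl gives a 1.5-fold higher number from compound 1 to compound 3 (0.19 log units; within the scatter), and in place of cyclohexylsulfanyl it gives a 1.5-fold lower number from compound 2 to compound 3 (0.17 log units; within the scatter). This position on the aromatic carbon next to the ring nitrogen therefore accepts a ring of carbon only, and the single hydrogen-bond acceptor counted in pyrrolidin-1-yl is not needed to keep the number in this range. No evidence at hand accounts for this. On these data alone, whether a small methyl, a phenyl ring or a morpholine ring would serve equally at this position stays open, as does the contribution of the methyl on the cyclohexyl ring.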